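Swapping one aromatic ring in compound 2

The source may hold more compounds than are shown below. What is called first, only, known or untested is meant among the compounds shown, and "the series" means these compounds.

- compound 1 `Cc1ccc(S(=O)(=O)/C(=C/c2ccc(C)s2)C(=O)c2ccc(Br)cc2)cc1` gives 25000 nM
- compound 2 `Cc1cc(C)cc(/C=C(\C(=O)c2ccc(Br)cc2)S(=O)(=O)Cc2ccc(F)cc2)c1` gives 10000 nM

In a functional assay on DU-145 cells (Homo sapiens) for inhibition, read by trypan blue exclusion, with a stated time of 96 h (on this read-out lower numbers stand for stronger inhibition of growth and higher numbers for weaker inhibition of growth), compound 2 has the lower of the two numbers, and the gap up to compound 1 lies beyond the usual scatter. Compound 3 `Cc1ccc(/C=C(\C(=O)c2ccc(Br)cc2)S(=O)(=O)Cc2ccc(F)cc2)s1` carries 5-methylthiophen-2-yl in place of 3,5-dimethylphenyl on a double-bonded chain carbon bound to a double-bonded chain carbon. Among the compounds with values here, no measured pair shows this change alone. Compound 1 also carries 5-methylthiophen-2-yl, differs elsewhere too, and gives 25000 nM in this assay, so a small rise within the scatter is expected. The expected step of a 1.4-fold higher number from compound 2 to compound 3 (0.15 log units; within the scatter) is therefore modest. For compound 3 the estimated value is 14000 nM (range 4000 nM to 40000 nM).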

Compound 3, concentration for 50% growth inhibition: 1000 nM
Compound 3: middle estimate off by 14-fold (1.15 log units), on the high side; the measured number lies below the stated range.
By their numbers in this assay, from the lowest: compound 3; then compound 2; then compound 1.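

In this assay, within the data shown here, 5-methylthiophen-2-yl in place of 3,5-dimethylphenyl gives a 10-fold lower number from compound 2 to compound 3 (1.00 log units; beyond the scatter), the first single-change reading at this double-bonded chain carbon. With 5-methylthiophen-2-yl held fixed, 4-fluorobenzyl in place of 4-methylphenyl on the sulfonyl sulfur gives a 25-fold lower number from compound 1 to compound 3 (1.40 log units; beyond the scatter), so the weak result of compound 1 does not count against 5-methylthiophen-2-yl when the sulfonyl group carries 4-fluorobenzyl. Nothing measured here explains either step. As far as these compounds go, whether a pyridin-3-yl or a 5-chlorothiophen-2-yl would do as well at this carbon stays open, as does whether the ring's methyl is needed.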